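A few compounds are considered here, and "the series" means these few. Any claim that something is new, unique, unknown or untested is made for them only; others in the source may bear on it.

The measured compounds:
Compound 1, `CN1C[C@H](C(=O)Nc2ccc(F)cc2)[C@@H](c2ccc(/C=C/C(=O)Nc3ccccc3N)cc2)C1`, gives 5 mL/min/kg in an in vitro ADME assay on microsomes from liver (Homo sapiens) for pharmacokinetics, read by LC-MS, with a stated time of 10 min, tested at 1 uM; on this read-out lower numbers stand for slow clearance and higher numbers for fast clearance.
Compound 2, `CN1C[C@H](C(=O)Nc2cccc(Cl)c2)[C@@H](c2ccc(/C=C/C(=O)Nc3ccccc3N)cc2)C1`, gives 7 mL/min/kg in this assay.
Compound 3, `Cc1cccc(NC(=O)[C@H]2CN(C)C[C@@H]2c2ccc(/C=C/C(=O)Nc3ccccc3N)cc2)c1`, gives 14 mL/min/kg in this assay.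

Compound 3 carries the highest of the three numbers in this assay. Its nearest neighbour is compound 2, with the step of a 2.0-fold higher number from compound 2 to compound 3 (0.30 log units; within the scatter), and the step of a 2.8-fold higher number from compound 1 to compound 3 (0.45 log units; beyond the scatter) is the only one among the three that lies beyond the scatter. The remaining step, a 1.4-fold higher number from compound 1 to compound 2 (0.15 log units; within the scatter), is within the scatter.

Compound 4, `Cc1ccc(NC(=O)[C@H]2CN(C)C[C@@H]2c2ccc(/C=C/C(=O)Nc3ccccc3N)cc2)cn1`, has not yet been measured. It differs from compound 3 in one place: 6-methylpyridin-3-yl in place of 3-methylphenyl on an amide-type nitrogen. Within the data shown here, none of the measured steps exchanges a six-membered aromatic ring of carbon only for a ring with a hetero atom; the measured steps only vary the groups on a ring of carbon. They show that changes at this amide-type nitrogen shift the number by modest amounts, the largest being a 2.8-fold higher number from compound 1 to compound 3 (0.45 log units; beyond the scatter). Among the measured compounds shown here, with no direct precedent, the step from compound 3 is expected to be modest and, if anything, downward, a 1.6-fold lower number from compound 3 to compound 4 (0.19 log units; within the scatter), and not clearly beyond the scatter. Compound 4 is therefore estimated at 9 mL/min/kg, within a range of 4 mL/min/kg to 20 mL/min/kg.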

Compound 4, clearance: 8 mL/min/kg
Estimate against measurement, compound 4: 1.1-fold (0.05 log units) above; the measured number falls inside the stated range.
By their numbers in this assay, from the lowest: compounds 1, 2, 4 and 3 (each within the scatter of the next, the first and the last beyond it).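

Among these compounds, the pair of compound 3 and compound 4 is the first at this amide-type nitrogen in which a six-membered aromatic ring of carbon only gives way to a ring with a hetero atom, and in this assay this exchange of 3-methylphenyl for 6-methylpyridin-3-yl, which brings in one hydrogen-bond acceptor, gives a 1.8-fold lower number from compound 3 to compound 4 (0.24 log units; within the scatter) and so stays inside the scatter. Set against the 3-chlorophenyl and 4-fluorophenyl groups, the new ring gives a 1.1-fold higher number from compound 2 to compound 4 (0.06 log units; within the scatter) and a 1.6-fold higher number from compound 1 to compound 4 (0.20 log units; within the scatter) and thus cannot be told apart from any of the three earlier compounds, although the earlier step of a 2.8-fold higher number from compound 1 to compound 3 (0.45 log units; beyond the scatter) still separates two of them. Nothing measured here explains these numbers.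

Still open, from the compounds shown here alone, is whether the methyl group on the new ring plays any part, which plain pyridin-3-yl would test, and whether the same exchange holds when the ring carries a chloro or fluoro group instead. The compounds shown also leave open how the number would respond to a ring bearing an amine or a carboxylic acid on this amide-type nitrogen.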